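The compounds below may be only part of what the source reports. "The series", "measured", "known", "first", "only" and "open" are said of these compounds alone.

Three compounds of the shared core have numbers in an assay on MDA-MB-231 cells for binding affinity to C-X-C chemokine receptor type 4 (Homo sapiens), read by immunofluorescence and microscopy, with stated times of 10 min and 30 min; a higher number here means that more compound is needed for the effect, a lower number that less compound is needed. Among the compounds with values here, compound 1 `O=C(NCc1ccc(CNS(=O)(=O)c2ccccc2)cc1)c1ccc(F)cc1` gives 100 nM and compound 3 `O=C(NCc1ccc(CNS(=O)(=O)c2ccccc2)cc1)c1ccc([N+](=O)[O-])cc1` gives 100 nM; the step of no change at the digits printed from compound 1 to compound 3 (within the scatter) is the only single-point step among them. Compound 2 `COc1cccc(C(=O)NCc2ccc(CNS(=O)(=O)c3ccc(C)cc3)cc2)c1` gives 10 nM, the lowest of the three, separated from each of the others by a step beyond the scatter. Compound 4 `Cc1ccc(S(=O)(=O)NCc2ccc(CNC(=O)c3cccc(C)c3)cc2)cc1` differs from compound 2 by methyl in place of methoxy on an aromatic carbon. Within the data shown here, no measured step bears on this change: the single step recorded sits on the other aromatic ring, and compound 2 differs from compounds 1 and 3 at more than one place. Compound 4 is therefore expected to stay close to compound 2, with a 1.5-fold higher number from compound 2 to compound 4 (0.18 log units; within the scatter) not beyond the scatter. The estimate for compound 4 is 15 nM, in the range 5 nM to 50 nM.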

Compound 4, effective concentration (reported as EC, without a stated level of effect): 1000 nM
For compound 4 the middle estimate is 67-fold (1.82 log units) below the measured one; the measured number lies above the stated range.
By their numbers in this assay, from the lowest: compound 2; then compounds 1 and 3 (each within the scatter of the next); then compound 4.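

Methyl in place of methoxy at this position, meta to a large group, gives a 100-fold higher number from compound 2 to compound 4 (2.00 log units; beyond the scatter) in this assay, so the number depends strongly on this substituent. The fluoro to nitro exchange gave no such sign, with no change at the digits printed from compound 1 to compound 3 (within the scatter) at its own position. Nothing measured accounts for the size of this step.

Open, from the compounds shown here alone, is whether a hydroxyl, an amine or a carboxylic acid at this position would stay near compound 2 or near compound 4. Also open, going by these compounds, is whether methoxy has the same effect on the core of compound 1.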